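This account rests on a few compounds, and the source may have more. Where it says the series, first, only, none or still open, it means among the compounds named here.

Measured so far:
compound 1 `Oc1ccc(-c2cc(-c3ccoc3)cc(-c3cccc(O)c3)n2)cc1`, 1.3%
compound 2 `Oc1ccc(-c2cc(-c3ccccn3)cc(-c3cccc(O)c3)n2)cc1`, "not determined" (no result reported)

In an assay on isolated protein for inhibition of DNA topoisomerase 1 (Homo sapiens), with a stated time of 30 min, tested at 20 uM (on this read-out higher numbers stand for a stronger effect at the one concentration tested and lower numbers for a weaker effect), compound 1 gives 1.3%, a weak effect at the concentration tested. Compound 2 has no single number in this assay, so its standing cannot be placed from the data at hand. Compound 3 `Oc1ccc(-c2cc(-c3cccnc3)cc(-c3cccc(O)c3)n2)cc1` differs from compound 2 by pyridin-3-yl in place of pyridin-2-yl on an aromatic carbon. Going by the values given here, no measured step exists for this pair; the expected step in this assay between compound 2 and compound 3 is none beyond the scatter, and the only anchor for the series is compound 1 with 1.3%. Compound 3 is expected to give about 3%, within a range of -8% to 15%.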

Compound 3, a percentage reported as inhibition, at one concentration (the size of the read-out at that concentration, not a potency): 2.8%
Compound 3: the middle estimate sits 0.2 percentage points above what was measured; measured number inside the range.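

Opposite the ring nitrogen, pyridin-3-yl in place of furan-3-yl gives a number 1.5 percentage points higher from compound 1 to compound 3 (within the scatter) in this assay and so provides the first readable step at this position: exchanging one aromatic ring for another leaves the effect weak at the one concentration tested. Nothing available explains this result. The pair of compound 2 and compound 3 cannot be read as a step.

Still open, going by these compounds, is whether an amine, a carboxylic acid or a longer alkyl chain at this position would move the read-out beyond the scatter.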